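The source may hold more compounds than are shown below. What is called first, only, known or untested is meant among the compounds shown, and "the series" means these compounds.

Measured in a functional assay on MCF-10A cells (Homo sapiens) for antiproliferative activity, with a stated time of 48 h; a higher number here means that more compound is needed for the effect, a lower number that less compound is needed:
compound 1 `COc1ccc2nc(C)cc(NCc3ccccc3)c2c1`: 28600 nM
compound 2 `COc1ccc2nc(C)cc(NCc3cccnc3)c2c1`: 49300 nM
compound 3 `COc1ccc2nc(C)cc(SCc3ccc(F)cc3)c2c1`: 50500 nM

Compound 3, at 50500 nM, lies within the scatter of the other two compounds, so these three values cannot be ranked. Compound 4 `COc1ccc2nc(C)cc(SCc3ccccc3)c2c1` differs from compound 3 by one change: hydrogen in place of fluoro on an aromatic carbon. For the measured compounds named here, no measured step covers this change. Going by the values given here, the only measured step, a 1.7-fold higher number from compound 1 to compound 2 (0.24 log units; within the scatter), sits elsewhere, replacing phenyl with pyridin-3-yl, and offers just a weak hint that a small change need not shift the value. No step beyond the scatter is therefore expected in this assay. The expected step is a 1.1-fold lower number from compound 3 to compound 4 (0.05 log units; within the scatter). For compound 4 the estimate is 45000 nM, with an expected range of 22000 nM to 90000 nM.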

Compound 4, half-maximal effective concentration: 37100 nM
For compound 4 the middle estimate is 1.2-fold (0.08 log units) above the measured one, and the stated range covers the measured number.
By their numbers in this assay, from the lowest: compounds 1, 4, 2 and 3 (each within the scatter of the next).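

In this assay, hydrogen in place of fluoro on an aromatic carbon, para to a large group, gives a 1.4-fold lower number from compound 3 to compound 4 (0.13 log units; within the scatter) and so does not separate the two compounds. For the compounds shown here, this is the first step read at this place, and it shows that going from 4-fluorophenyl to phenyl leaves the value within the scatter. Nothing available bears on the reason for this result. On these data alone, whether a chloro, methoxy or amine group at this place would also stay within the scatter remains open, as does whether the same exchange would read alike on compound 1.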